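Chloro Added to a Second Core: What to Expect

A few compounds are considered here, and "the series" means these few. Any claim that something is new, unique, unknown or untested is made for them only; others in the source may bear on it.

Compound 3 `N=c1c(=O)[nH]nc2n1CCN2c1ccccc1` and compound 2 `N=c1c(=O)[nH]nc2n1CCN2c1cccc(Cl)c1` share one core and differ in a single place: chloro in place of hydrogen on an aromatic carbon. In a functional assay on T47D cells (Homo sapiens) for cytotoxicity, with a stated time of 72 h, tested at 10 ug/mL (on this read-out lower numbers stand for a weaker effect and higher numbers for a stronger effect at the one concentration tested), compound 3 gives 0%, and compound 2 gives 3%. The step of a number 3 percentage points higher from compound 3 to compound 2 (within the scatter) lies within the scatter, so this change left the read-out essentially where it was.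

Compound 1 `O=c1[nH]nc2n(c1=O)CCN2c1ccccc1` is built on a different core; the difference between the two cores is not broken down here. In this assay compound 1 gives 0%, level with compound 3 at the digits reported, and both stand together as the lowest of the three numbers. Compound 4 `O=c1[nH]nc2n(c1=O)CCN2c1cccc(Cl)c1` has not yet been measured. It differs from compound 1 in the same way that compound 2 differs from compound 3: chloro in place of hydrogen on an aromatic carbon. The place is described in the same words for both pairs, so the change is of the same kind.

The step expected from compound 1 to compound 4 is a number 3 percentage points higher from compound 1 to compound 4 (within the scatter), resting on the earlier step of a number 3 percentage points higher from compound 3 to compound 2 (within the scatter), which stayed within the scatter. Compound 4 is therefore estimated at about 3%, with a range from 0% to 12%.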

Compound 4, a percentage reported as inhibition, at one concentration (the size of the read-out at that concentration, not a potency): 0%
Compound 4: the middle estimate sits 3 percentage points above what was measured, within the range that was stated.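

In this assay, the new step for chloro in place of hydrogen on an aromatic carbon is no change at the digits printed from compound 1 to compound 4 (within the scatter), and it agrees with the same change on the other core: the same change on two cores in this assay, a number 3 percentage points higher (within the scatter) from compound 3 to compound 2 and no change at the digits printed (within the scatter) from compound 1 to compound 4, 3 percentage points apart, within the scatter of two such steps. For these two pairs, then, the change carries over in a modest sense: on both cores it leaves the read-out essentially where it was. This does not show that a real effect of chloro passes from one core to the other, as neither step rises above the scatter, so there is no clear effect to follow across the cores.

The compounds shown leave open whether a different group on that aromatic carbon, such as an amine, a carboxylic acid or a longer chain, would move the read-out on either core. They also leave open whether a step beyond the scatter in this assay on one core would reappear on the other.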